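Alkoxy variation on the shared core: toward cyclohexylmethoxy

The source may hold more compounds than are shown below. What is called first, only, known or untested is meant among the compounds shown, and "the series" means these compounds.

Measured compounds:
compound 1 `CCN(CC)C(=O)Cc1c(-c2ccc(OC(C)C)cc2)nn2c(C)cc(C)nc12` gives 2.2 nM
compound 2 `CCN(CC)C(=O)Cc1c(-c2ccc(OC3CCC3)cc2)nn2c(C)cc(C)nc12` gives 0.86 nM
compound 3 `CCN(CC)C(=O)Cc1c(-c2ccc(OCC3CC3)cc2)nn2c(C)cc(C)nc12` gives 3 nM

All three values come from an assay on isolated protein (kidney, strain Wistar) for displacement of a labelled ligand from Translocator protein (Rattus norvegicus), read by scintillation counting, with a stated time of 90 min; a higher number here means a weaker inhibitor, a lower number a stronger inhibitor. Within this small set, compound 3 carries the highest number: one of the two steps that end at it is a 1.4-fold higher number from compound 1 to compound 3 (0.13 log units; within the scatter), which stays within the scatter, while the other is a 3.5-fold higher number from compound 2 to compound 3 (0.54 log units; beyond the scatter), which lies beyond it. So compound 3 and compound 1 cannot be separated, and compound 2 stands apart with the lowest number.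

The next compound, compound 4 `CCN(CC)C(=O)Cc1c(-c2ccc(OCC3CCCCC3)cc2)nn2c(C)cc(C)nc12`, is not yet measured. It differs from compound 3 in one place: cyclohexyl in place of cyclopropyl on a saturated chain carbon bound to an oxygen on an aromatic ring. The two measured steps that touch the same position are the move from isopropyl to cyclopropylmethyl, a 1.4-fold higher number from compound 1 to compound 3 (0.13 log units; within the scatter), and the move from cyclobutyl to cyclopropylmethyl, a 3.5-fold higher number from compound 2 to compound 3 (0.54 log units; beyond the scatter). Neither step enlarges the group as far as the present change does; all three measured variants remain close to one another, with the widest spread being a 3.5-fold higher number from compound 2 to compound 3 (0.54 log units; beyond the scatter). Within the data shown here, no measured compound carries a group of the size now entering, so the direction is open. Given the small spread seen so far, the step for compound 4 is expected to be a 1.7-fold higher number from compound 3 to compound 4 (0.22 log units; within the scatter), modest and most likely toward a higher number. Compound 4 is therefore estimated at 5 nM, with a range from 1.5 nM to 20 nM in this assay .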

Compound 4, inhibition constant: 3.6 nM
Beside the measured number, compound 4's estimate is 1.4-fold (0.14 log units) above it; the range from low to high includes it.
By their numbers in this assay, from the lowest: compound 2; then compounds 1, 3 and 4 (each within the scatter of the next).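

Cyclohexyl in place of cyclopropyl on a saturated chain carbon bound to an oxygen on an aromatic ring gives a 1.2-fold higher number from compound 3 to compound 4 (0.08 log units; within the scatter) in this assay, so this position accepts a group of this size with no change that can be separated from the scatter. Compound 4 also cannot be separated from the isopropyl ether, with a 1.6-fold higher number from compound 1 to compound 4 (0.21 log units; within the scatter), whereas a 4.2-fold higher number from compound 2 to compound 4 (0.62 log units; beyond the scatter) confirms that the cyclobutyl ether, compound 2, is the only one of the four that stands apart, and it is the exception to an otherwise flat set. No supporting data here explain why cyclohexylmethyl is accepted or why cyclobutyl stands apart.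

Still open, going by these compounds, is whether the lower number of compound 2 extends to cyclopentyl or cyclohexyl bound directly to the oxygen, since only cyclobutyl shows it so far. Also open, on these data alone, is how the number responds to a longer chain such as cyclohexylethyl, or to an amine or a carboxylic acid at the end of the chain on the oxygen.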